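The source may hold more compounds than are shown below. What is called first, only, known or untested is meant among the compounds shown, and "the series" means these compounds.

In a functional assay on U-87MG ATCC cells for inhibition, with U-87 MG (Homo sapiens) as the target, read by MTT assay, with a stated time of 48 h (a higher number here means a weaker inhibitor, a lower number a stronger inhibitor), three compounds have been tested so far. Compound 1 `CCc1ccc(-c2nc3ccccn3c2Sc2ccccc2)cc1` gives 61700 nM, and compound 3 `CS(=O)(=O)c1ccc(-c2nc3ccccn3c2Sc2cccc3ccccc23)cc1` gives 56200 nM. Among the measured compounds shown here, these two numbers lie within the usual scatter of repeated measurements, so compound 1 stands level with the only other compound that has a true number. Compound 2 `Clc1ccc2nc(-c3ccccc3)c(Sc3ccccc3)n2c1` gives > 100000 nM, which is a limit of the assay and not a number.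

The next compound to be tested is compound 4 `c1ccc(Sc2c(-c3cccs3)nc3ccccn23)cc1`. It is made from compound 1 by one change on an aromatic carbon of the core, with thiophen-2-yl in place of 4-ethylphenyl on an aromatic carbon. The phenylsulfanyl group stays as it is. For the measured compounds named here, no pair of tested compounds isolates a change of this kind, so there is no measured step to borrow, and the expectation has to stay modest.

In this assay, no step beyond the scatter is expected, and so no clear direction either. Going by the values given here, the only guide is that compound 3, at 56200 nM, falls in the same range as compound 1. The expected value for compound 4 is 70000 nM, with an estimated range of 30000 nM to 100000 nM. This estimate means a step of a 1.1-fold higher number from compound 1 to compound 4 (0.05 log units; within the scatter), which is expected to stay within the scatter. A result reported only as a limit also remains possible.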

Compound 4, half-maximal inhibitory concentration: > 100000 nM
Compound 4: a limit, no number; the forecaster's own chance of this, stated with the estimate: 30%; at least 1.4-fold (0.15 log units) between middle value and limit.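

In this assay, this position on an aromatic carbon of the core, next to the ring nitrogen, now has its first measured change: replacing 4-ethylphenyl with thiophen-2-yl gives an at least 1.6-fold higher number from compound 1 to compound 4 (0.20 log units; that floor lies within the scatter). This step is only a floor, so the true size of the change cannot be read, and with that floor inside the scatter, the result alone does not prove that the swap weakens the compound. What it does show is that this five-membered ring with one sulfur brings no measurable gain over 4-ethylphenyl, as compound 4 gives > 100000 nM, a limit of the assay and not a number, and this end of the range is already crowded: the limit of > 100000 nM in this assay, at which 2 of the 4 values shown sit.

The compounds shown leave open whether any group at this position can give a number clearly lower than that of compound 1, for example a phenyl ring carrying an amine or a carboxylic acid. They also leave open how a longer chain in place of the ethyl of 4-ethylphenyl would behave, and whether the number depends on that chain at all.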